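The compounds below may be only part of what the source reports. "The series", "measured", "known", "first", "only" and "open" are said of these compounds alone.

Measured so far:
compound 1, `COC(=O)c1cccc(OCc2oc(-c3ccccc3OC)nc2C)c1`: 44100 nM
compound 2, `COC(=O)c1cccc(OCc2oc(-c3cccc(OC)c3)nc2C)c1`: 24100 nM
compound 3, `COC(=O)CCc1ccc(OCc2oc(-c3ccccc3OC)nc2C)cc1`: 62600 nM

Of the compounds shown here, three have been measured in a physicochemical assay for solubility, tested at 500 uM; a lower number here means a less soluble compound, a higher number a more soluble compound. Compound 1, `COC(=O)c1cccc(OCc2oc(-c3ccccc3OC)nc2C)c1`, gives 44100 nM in this assay. Compound 2, `COC(=O)c1cccc(OCc2oc(-c3cccc(OC)c3)nc2C)c1`, gives 24100 nM. Compound 3, `COC(=O)CCc1ccc(OCc2oc(-c3ccccc3OC)nc2C)cc1`, gives 62600 nM.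

Compound 1 and compound 2 differ in one place, (3-methoxyphenyl in place of 2-methoxyphenyl on an aromatic carbon), and the step between them is a 1.8-fold lower number from compound 1 to compound 2 (0.26 log units; within the scatter). Compound 3 shares with compound 1 the same 2-methoxyphenyl on the five-membered ring but carries a different core; the difference between the two cores is not broken down here. Its value lies within the scatter of compound 1, while compound 2 reads lower than compound 3 by more than the scatter.

Compound 4, `COC(=O)CCc1ccc(OCc2oc(-c3cccc(OC)c3)nc2C)cc1`, has not yet been measured. It differs from compound 3 by 3-methoxyphenyl in place of 2-methoxyphenyl on an aromatic carbon, and the place is described in the same words as for the step from compound 1 to compound 2, so the change is the same one. The expectation for compound 4 rests on that single measured step: the step from compound 3 to compound 4 is expected to be a 1.8-fold lower number from compound 3 to compound 4 (0.25 log units; within the scatter), because of a 1.8-fold lower number from compound 1 to compound 2 (0.26 log units; within the scatter). On that basis compound 4 is estimated to give 35000 nM in this assay, most likely between 17000 nM and 70000 nM.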

Compound 4, solubility: 38200 nM
Compound 4: the middle estimate sits 1.1-fold (0.04 log units) below what was measured, within the range that was stated.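

Placing 3-methoxyphenyl where 2-methoxyphenyl stood has now been read on two different cores in this assay, giving a 1.8-fold lower number from compound 1 to compound 2 (0.26 log units; within the scatter) on the first core and a 1.6-fold lower number from compound 3 to compound 4 (0.21 log units; within the scatter) on the second. The two steps point the same way and are similar in size, so this small set gives no sign that the core alters what the change does, and the reading from the first core carried over to the second. Each step lies within the scatter, however, so neither pair shows that the change truly moves the read-out, and two pairs cannot show that it would behave alike on every core, while nothing measured here explains the result.

The compounds shown all keep the methyl ester, so they leave open whether the same change would read alike on a core carrying a carboxylic acid or an amine in its place. They also leave open what happens on cores with a longer chain between the ester and the aromatic ring, where a further pair would test how far this agreement reaches.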